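From trifluoromethyl to ethoxy on an aromatic ring

This account rests on a few compounds, and the source may have more. Where it says the series, first, only, none or still open, it means among the compounds named here.

In a functional assay on MCF7 cells (Homo sapiens) for inhibition, read by sulforhodamine B assay (a higher number here means a weaker inhibitor, a lower number a stronger inhibitor), compound 3 (`O=C1C(Nc2ccc(C(F)(F)F)cc2)=CC(=O)c2c1nc1n2[C@H]2OC[C@@H](O)[C@H]2OC1`) has no exact number, only the limit > 4000 nM. Compound 1 (`O=C1C(NC2CCCC2)=CC(=O)c2c1nc1n2[C@H]2OC[C@@H](O)[C@H]2OC1`) is also known only by a limit, > 16000 nM. Compound 2 (`CCc1ccc(NC2=CC(=O)c3c(nc4n3[C@H]3OC[C@@H](O)[C@H]3OC4)C2=O)cc1`) gives a measured value of 8990 nM.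

Compound 4 (`CCOc1ccc(NC2=CC(=O)c3c(nc4n3[C@H]3OC[C@@H](O)[C@H]3OC4)C2=O)cc1`) carries ethoxy in place of trifluoromethyl on an aromatic carbon, para to a large group: ethoxy in place of trifluoromethyl on an aromatic carbon.

For the measured compounds named here, two measured steps bear most directly on this change. One is a step that the limit leaves unreadable from compound 2 to compound 3, which swaps the same position between ethyl and trifluoromethyl. The other is an at least 1.7-fold lower number from compound 1 to compound 2 (0.25 log units; that floor lies within the scatter), so it does not establish a gain either. Neither gives a readable size for a change at this position, and the limit on compound 3 leaves the starting point open. Going by the values given here, the expectation therefore rests on compound 2 at 8990 nM, the only exact number in the set, and points to continued weak inhibition. The expected change is a step that the limit leaves unreadable from compound 3 to compound 4. For compound 4 the estimate is 7000 nM, with an expected range from 2500 nM to 16000 nM.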

Compound 4, half-maximal inhibitory concentration: > 4000 nM
Compound 4: a limit, no number (the forecaster's own chance of this, stated with the estimate: 30%); the middle value lies beyond the limit too.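

In this assay compound 4 gives only a limit, > 4000 nM. The steps to compound 4 from compound 1, compound 2 and compound 3 cannot be read. The compounds shown leave open whether ethoxy, ethyl or trifluoromethyl on the aromatic carbon makes any difference to inhibition.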